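The source may report more compounds than this note shows. Statements on the series, on what has been measured and on what is new or still open speak of the compounds shown alone.

Of the compounds shown here, three sharing one core have been tested in an assay on isolated protein for inhibition of protein kinase C zeta type (Homo sapiens), with stated times of 1 h and 2.5 min, tested at 30 uM; a higher number here means more inhibition at the concentration tested (going by the name of the read-out), a lower number less inhibition. Compound 1 `CCOC(=O)c1c(-c2cccc(C)c2)csc1N` gives 77% there, and compound 2 `CCOC(=O)c1c(-c2cccc(OC)c2)csc1N` gives 82%, a change of a number 5 percentage points higher from compound 1 to compound 2 (within the scatter) that says nothing firm. Compound 3 `CCOC(=O)c1c(-c2cccc(F)c2)csc1N` gives 38% and stands lowest of the three: the step of a number 39 percentage points lower from compound 1 to compound 3 (beyond the scatter) and the step of a number 44 percentage points lower from compound 2 to compound 3 (beyond the scatter) are both large and clearly beyond the scatter, so the fluoro compound has the lowest number in this assay among those measured.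

Compound 4 `CCOC(=O)c1c(-c2cccc(C#N)c2)csc1N` carries the change (cyano in place of fluoro on an aromatic carbon). Among the measured compounds shown here, no measured step involves a cyano group, so the only guidance is that the fluoro of compound 3 sits far below both the methyl of compound 1 and the methoxy of compound 2. That suggests the low value of compound 3 is tied to fluoro rather than to the core, and that replacing it could move the number back up, but the two earlier steps do not say how a cyano group will behave, so the range must be wide.

Compound 4 is therefore expected to give about 55%, with a likely range from 25% to 85%. The expected step is a number 17 percentage points higher from compound 3 to compound 4 (beyond the scatter), upward but uncertain.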

Compound 4, a percentage reported as inhibition, at one concentration (the size of the read-out at that concentration, not a potency): 32%
The estimate for compound 4 lay 23 percentage points above the measured number; low and high end bracket the measured number.
By their numbers in this assay, from the lowest: compounds 4 and 3 (each within the scatter of the next); then compounds 1 and 2 (each within the scatter of the next).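

In this assay, putting cyano in place of fluoro on the aromatic carbon gives a number 6 percentage points lower from compound 3 to compound 4 (within the scatter), so these two groups cannot be told apart at this position. The same compound sits far from the other two, with a number 50 percentage points lower from compound 2 to compound 4 (beyond the scatter) for cyano in place of methoxy and a number 45 percentage points lower from compound 1 to compound 4 (beyond the scatter) for cyano in place of methyl, both large steps, so the low number of compound 3 is no longer a result for fluoro alone: the four groups now fall into a high pair, methyl and methoxy, and a low pair, fluoro and cyano. Nothing available here bears on why the groups divide in this way.

From the compounds shown here alone, four groups are too few to give a rule, so it remains open whether a hydroxyl, a chloro or an ethyl group at this same place would join the high pair, the low pair or neither. It is also open whether the same division would hold on a core with a carboxylic acid in place of the ester, and a reading at one concentration gives no measure of potency for any of these compounds.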